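The source may report more compounds than this note shows. Statements on the series, on what has been measured and on what is new or still open speak of the compounds shown alone.

Compound 3 `C[C@H](Nc1nc(N)nc(N)c1C#N)c1c(-c2ccccc2)c(=O)n2cc(F)ccc2c1-c1ccccc1` is one of three compounds that share a core and carry a hydrogen, a cyclopropyl or a phenyl on the same aromatic carbon. In an ADME assay on microsomes from liver (Rattus norvegicus), read by LC-MS, using NADPH, with a stated time of 30 min, tested at 1 uM (a higher number here means that more of the compound is left, a lower number that less of the compound is left), compound 1 `C[C@H](Nc1nc(N)nc(N)c1C#N)c1cc2ccc(F)cn2c(=O)c1-c1ccccc1` gives 88%, compound 2 `C[C@H](Nc1nc(N)nc(N)c1C#N)c1c(-c2ccccc2)c(=O)n2cc(F)ccc2c1C1CC1` gives 84%, and compound 3 gives 73%. Compound 3 thus stands lowest of the three: the step of a number 15 percentage points lower from compound 1 to compound 3 (beyond the scatter) and the step of a number 11 percentage points lower from compound 2 to compound 3 (beyond the scatter) both lie beyond the scatter, whereas the step of a number 4 percentage points lower from compound 1 to compound 2 (within the scatter) does not.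

Compound 4 `C[C@H](Nc1nc(N)nc(N)c1C#N)c1c(-c2ccccc2)c(=O)n2cc(F)ccc2c1-c1ccc(C(N)=O)cc1` differs from compound 3 in one place: carbamoyl in place of hydrogen on an aromatic carbon. Going by the values given here, none of the measured steps touches this position; all three concern what sits on the aromatic carbon of the core, and compound 4 keeps the phenyl of compound 3 there. The record therefore gives no direct guide, and the expected step is a number 5 percentage points higher from compound 3 to compound 4 (within the scatter), which is not expected to exceed the scatter clearly in either direction. Compound 4 is accordingly estimated at 78%, with a range from 62% to 92%, in this assay.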

Compound 4, percent of the compound remaining: 100%
For compound 4 the middle estimate is 22 percentage points below the measured one; the measured number lies above the stated range.
By their numbers in this assay, from the lowest: compound 3; then compounds 2 and 1 (each within the scatter of the next); then compound 4.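

In this assay, going by these compounds alone, the outer phenyl of compound 3 proves to be a sensitive site: carbamoyl on its aromatic carbon, para to a large group, gives a number 27 percentage points higher from compound 3 to compound 4 (beyond the scatter), a change at a position the earlier compounds did not touch. Phenyl had given the lowest number of the first three compounds, whereas 4-carbamoylphenyl on the same core carbon reverses that standing, with a number 16 percentage points higher from compound 2 to compound 4 (beyond the scatter) and a number 12 percentage points higher from compound 1 to compound 4 (beyond the scatter), so a substituent on a hydrogen-, cyclopropyl- or phenyl-bearing series can turn a loss into a gain. Nothing available explains this rise.

The compounds shown leave open whether the gain belongs to carbamoyl itself or would also appear with a carboxylic acid or an amine at this place. On these data alone, whether carbamoyl would act alike elsewhere on the phenyl also remains open.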